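Working notes on compound 4: amide aryl exchange

This account rests on a few compounds, and the source may have more. Where it says the series, first, only, none or still open, it means among the compounds named here.

The set holds three measured compounds on a shared core: compound 1 `COc1ccccc1C(=O)Nc1nnc(SCC(=O)Nc2ccc(Cl)cn2)s1`, compound 2 `O=C(CCl)Nc1ccc(SCC(=O)Nc2ccc(Cl)cn2)cc1` and compound 3 `O=C(CCl)Nc1ccc(SCC(=O)Nc2ccc(Br)cn2)cc1`. In a functional assay on HeLa cells (Homo sapiens) for antiproliferative activity, read by MTT assay, with a stated time of 48 h (on this read-out lower numbers stand for stronger inhibition and higher numbers for weaker inhibition), compound 2 gives 2500 nM and compound 3 gives 2100 nM. Compound 1 reaches only the limit > 80000 nM, which is a limit of the assay and not a number, as noted in the limit of > 80000 nM in this assay, at which 1 of the 3 values shown sits. For the measured compounds named here, the single measured step, a 1.2-fold lower number from compound 2 to compound 3 (0.08 log units; within the scatter), lies within the scatter. Compound 3 thus holds the lowest of the two numbers, with compound 2 within the scatter of it, so no order between the two is claimed.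

Compound 4 `O=C(CCl)Nc1ccc(SCC(=O)Nc2ccc(Cl)cc2)cc1` differs from compound 3 by 4-chlorophenyl in place of 5-bromopyridin-2-yl on an amide-type nitrogen. Going by the values given here, no measured step covers this exchange of the aryl group on the amide nitrogen; the only measured step, a 1.2-fold lower number from compound 2 to compound 3 (0.08 log units; within the scatter), concerns a halogen on an aromatic carbon and was within the scatter. With no evidence for a shift in either direction, no step beyond the scatter is expected in this assay.

Compound 4 is therefore estimated at 2500 nM in this assay, with a range from 800 nM to 8000 nM. Among the compounds with values here, the step of a 1.2-fold higher number from compound 3 to compound 4 (0.08 log units; within the scatter) expected on this basis is small, and the range is wide because the exchange has no measured precedent here.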

Compound 4, half-maximal inhibitory concentration: > 80000 nM
Compound 4: a limit, no number; the forecaster's own chance of this, stated with the estimate: 10%; middle value at least 32-fold (1.50 log units) from the limit.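

In this assay the aryl group on the amide-type nitrogen now proves sensitive, whereas the halogen exchange on that group gave only a 1.2-fold lower number from compound 2 to compound 3 (0.08 log units; within the scatter): 4-chlorophenyl in place of 5-bromopyridin-2-yl gives an at least 38-fold higher number from compound 3 to compound 4 (1.58 log units; beyond the scatter), and 4-chlorophenyl in place of 5-chloropyridin-2-yl gives an at least 32-fold higher number from compound 2 to compound 4 (1.50 log units; beyond the scatter). Compound 2 and compound 4 both carry chlorine on this aryl group, so the second step separates a ring with a hetero atom from a ring of carbon only, without a change of halogen. Compound 4 gives > 80000 nM, which is a limit of the assay and not a number, so both steps fix only a minimum size: the limit of > 80000 nM in this assay, at which 2 of the 4 values shown sit.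

Still open, on these data alone, is whether the ring hetero atom is required for a measurable number or whether a phenyl group with an amine or a carboxylic acid in place of the chlorine would also give one. Also open, as far as these compounds go, is how far the pyridin-2-yl group tolerates other replacements for its halogen, such as a methyl or a methoxy group.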